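A few compounds are considered here, and "the series" means these few. Any claim that something is new, unique, unknown or untested is made for them only; others in the source may bear on it.

The compounds measured in a functional assay on BGC-823 cells (Homo sapiens) for antiproliferative activity, read by MTT assay, with a stated time of 48 h (on this read-out lower numbers stand for an effect already at smaller amounts and higher numbers for an effect only at larger amounts of compound), are these.
Compound 1, `O=C(Nc1nnc(-c2ccc3c(c2)OCCO3)s1)c1ccccc1`, gives 46.2 ug/mL.
Compound 2, `O=C(CCc1ccccc1)Nc1nnc(-c2ccc3c(c2)OCCO3)s1`, gives 14.2 ug/mL.
Compound 3, `O=C(Nc1nnc(-c2ccc3c(c2)OCCO3)s1)c1ccc(Cl)nc1`, reaches only > 100 ug/mL, which is a limit of the assay and not a number.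

Compound 2 holds the lowest of the two numbers; compound 1 stands nearest, and the move is a 3.3-fold lower number from compound 1 to compound 2 (0.51 log units; beyond the scatter). Compound 3 sits at the limit of > 100 ug/mL in this assay, at which 1 of the 3 values shown sits.

Compound 4, `O=C(/C=C/c1ccccc1)Nc1nnc(-c2ccc3c(c2)OCCO3)s1`, differs from compound 2 by 2-phenylethenyl in place of phenethyl on a carbonyl carbon. For the measured compounds named here, the steps that bear on this position are a 3.3-fold lower number from compound 1 to compound 2 (0.51 log units; beyond the scatter) and an at least 7.0-fold higher number from compound 2 to compound 3 (0.84 log units; beyond the scatter): both replace the whole group on the carbonyl carbon, and both are modest. Neither step keeps the same chain length while adding a double bond outside aromatic rings, so none of them measures the change made here. The expectation is therefore a step no larger than the scatter, in no settled direction, with compound 4 staying near compound 2.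

For compound 4 the estimated step is a 1.0-fold lower number from compound 2 to compound 4 (0.01 log units; within the scatter), with the expected value 14 ug/mL and a range from 5 ug/mL to 40 ug/mL.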

Compound 4, half-maximal effective concentration: 45.4 ug/mL
For compound 4 the middle estimate is 3.2-fold (0.51 log units) below the measured one; the whole stated range lies below it.
By their numbers in this assay, from the lowest: compound 2; then compounds 4 and 1 (each within the scatter of the next). At a limit, above all of these: compound 3.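

In this assay this position responds to a change that leaves the carbon count of the group alone and adds only one double bond outside aromatic rings: a 3.2-fold higher number from compound 2 to compound 4 (0.50 log units; beyond the scatter). The 2-phenylethenyl and phenyl groups on the carbonyl carbon cannot be told apart on this read-out, with a 1.0-fold lower number from compound 1 to compound 4 (0.01 log units; within the scatter), so the saturated phenethyl group alone stands beyond the scatter from both. Compound 3 remains at a limit of the assay and not a number, so an at least 2.2-fold lower number from compound 3 to compound 4 (0.34 log units; beyond the scatter) gives a bound only.

Nothing shown here accounts for the effect of the double bond. Also open, as far as these compounds go, is how an amine, a carboxylic acid or a longer chain ending in phenyl on the carbonyl carbon would read in this assay.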